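Replacing a Formyl Group with a Bulkier Amine

The source may hold more compounds than are shown below. What is called first, only, known or untested is meant among the compounds shown, and "the series" means these compounds.

Of the compounds shown here, two built on closely related cores have numbers so far in a functional assay on MCF7 cells (Homo sapiens) for antiproliferative activity, read by MTT assay, with a stated time of 48 h (on this read-out higher numbers stand for weaker inhibition and lower numbers for stronger inhibition), and they sit close together. There compound 1 `COC/C1=C/C[C@](C)(CCC=C(C)C)/C=C/[C@@H](OC(=O)C=C(C)C)[C@](C)(OC)/C=C/C1=O` gives 16500 nM while compound 2 `CC(C)=CCC[C@]1(C)/C=C/[C@@H](OC(=O)C=C(C)C)[C@](C)(O)/C=C/C(=O)/C(C=O)=C\C1` gives 12600 nM as its value, so the two lie within the usual scatter of each other.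

Compound 3 `CC(C)=CCC[C@]1(C)/C=C/[C@@H](OC(=O)C=C(C)C)[C@](C)(O)/C=C/C(=O)/C(CN(C(C)C)C(C)C)=C\C1` carries (diisopropylamino)methyl in place of formyl on a double-bonded ring carbon and is otherwise the same as compound 2. Within the data shown here, no measured pair shows what such a swap does, so the only anchor is compound 2 at 12600 nM in this series. In this assay little change is expected, perhaps slightly toward stronger inhibition and nothing beyond the scatter, and the estimated move a 1.5-fold lower number from compound 2 to compound 3 (0.17 log units; within the scatter) stays small. The expected value for compound 3 is 8500 nM within an estimated range of 2800 nM to 25000 nM for repeated measurements.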

Compound 3, half-maximal inhibitory concentration: 780 nM
Compound 3: middle estimate off by 11-fold (1.04 log units), on the high side; measured number below the stated range.
By their numbers in this assay, from the lowest: compound 3; then compounds 2 and 1 (each within the scatter of the next).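

In this assay, among these compounds, this is the first change in a single place that can be read, and it gives a 16-fold lower number from compound 2 to compound 3 (1.21 log units; beyond the scatter). The double-bonded ring carbon is therefore far from a silent position: the number falls sharply when formyl, with 2 heavy atoms, gives way to (diisopropylamino)methyl, with 8 heavy atoms. Nothing measured here explains why the number falls.

The compounds shown leave open whether the nitrogen, the two isopropyl groups or simply the loss of the formyl group matters most. A smaller (dimethylamino)methyl group and a carbon-only chain such as isobutyl on the same ring carbon would help separate these possibilities.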